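This account rests on a few compounds, and the source may have more. Where it says the series, first, only, none or still open, it means among the compounds named here.

Measured in an ADME assay on the whole organism (plasma, Rattus norvegicus) for protein binding, using cassette dosing, at a dose of 1 mg/kg; a higher number here means a larger unbound share of the compound, a lower number a smaller unbound share:
- compound 1 `Cc1ccc(Cn2c(=O)n(CC(C)(C)C(=O)O)c(=O)[nH]/c2=N\c2ccc(OC(C)C)c(Cl)c2)cc1`: 0.01
- compound 2 `Cc1cc(/N=c2\[nH]c(=O)n(C[C@H](C)C(=O)O)c(=O)n2Cc2ccc(Cl)cc2)ccc1OC(C)C`: 0.02
- compound 3 `C[C@@H](Cn1c(=O)[nH]/c(=N\c2ccc(Oc3nccs3)cc2)n(Cc2ccc(Cl)cc2)c1=O)C(=O)O`: 0.006

Compound 3, at 0.006, cannot be told apart from compound 1, at 0.01. Compound 2, at 0.02, shows a larger unbound share than compound 3, and that gap lies beyond the scatter. Compound 4 `C[C@@H](Cn1c(=O)[nH]/c(=N\c2ccc(Oc3cncc(F)c3)cc2)n(Cc2ccc(Cl)cc2)c1=O)C(=O)O` carries 5-fluoropyridin-3-yl in place of 1,3-thiazol-2-yl on an oxygen on an aromatic ring. Among the measured compounds shown here, no measured pair isolates this swap, so the expectation rests on the value of its closest relative, compound 3 at 0.006. In this assay, the expected change is small, with no step beyond the scatter: a 1.2-fold lower number from compound 3 to compound 4 (0.08 log units; within the scatter). The estimate for compound 4 is 0.005, with an expected range from 0.002 to 0.012.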

Compound 4, unbound fraction: 0.02
Compound 4: middle estimate off by 4.0-fold (0.60 log units), on the low side, outside the stated range (above it).
By their numbers in this assay, from the lowest: compounds 3, 1, 2 and 4 (each within the scatter of the next, the first and the last beyond it).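

In this assay, the group on this oxygen proves able to shift the unbound share: 5-fluoropyridin-3-yl in place of 1,3-thiazol-2-yl gives a 3.3-fold higher number from compound 3 to compound 4 (0.52 log units; beyond the scatter). The earlier compounds shown here differed in more than one place, so they could not isolate this position. No available evidence explains the step.

The swap changes the ring and adds fluorine at once, so the two changes cannot be separated. From the compounds shown here alone, a plain pyridin-3-yl on the same oxygen would help separate them, and whether the step holds on other cores remains open.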